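Naphthalen-1-yl in place of 4-fluorophenyl on a sulfur

The source may report more compounds than this note shows. Statements on the series, on what has been measured and on what is new or still open speak of the compounds shown alone.

In a functional assay on SMMC-7721 cells (Homo sapiens) for inhibition, read by CCK-8 assay, with a stated time of 72 h, tested at 8 uM (on this read-out higher numbers stand for more inhibition of growth at the one concentration tested and lower numbers for less inhibition of growth), compound 1 `COc1ccc(SCc2ccc(/C=C/C(=O)Nc3ccccc3N)cc2)cc1OC` gives 44.6% and compound 2 `Nc1ccccc1NC(=O)/C=C/c1ccc(CSc2ccc(F)cc2)cc1` gives 15.4% as the lower of the two numbers. The change to compound 3 `Nc1ccccc1NC(=O)/C=C/c1ccc(CSc2cccc3ccccc23)cc1` is naphthalen-1-yl in place of 4-fluorophenyl on a sulfur with the rest of the structure untouched. Among the measured compounds shown here, only one measured step bears on this place: a number 29.2 percentage points lower from compound 1 to compound 2 (beyond the scatter) when the group on that sulfur was exchanged. It shows that a change here can count, but it gives no direction for naphthalen-1-yl. A modest rise is expected, a number 11.6 percentage points higher from compound 2 to compound 3 (beyond the scatter) in size, and smaller than the measured step. In this assay the estimate for compound 3 is 27% with an expected range from 10% to 47% as the likely span.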

Compound 3, percent growth inhibition at one concentration: 18.3%
Estimate against measurement, compound 3: 8.7 percentage points above, and the stated range covers the measured number.
By their numbers in this assay, from the lowest: compounds 2 and 3 (each within the scatter of the next); then compound 1.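

In this assay, naphthalen-1-yl, with two aromatic rings, in place of 4-fluorophenyl, with one, gives a number 2.9 percentage points higher from compound 2 to compound 3 (within the scatter) and so does not separate the two compounds. Naphthalen-1-yl in place of 3,4-dimethoxyphenyl gives a number 26.3 percentage points lower from compound 1 to compound 3 (beyond the scatter), so neither replacement shown matches compound 1, whether the incoming group has one ring or two. On these data alone, what a group carrying an amine or a carboxylic acid would give on that sulfur stays open. Nothing measured here explains why compound 1 stands apart.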